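The source may report more compounds than this note shows. Statements on the series, on what has been measured and on what is new or still open speak of the compounds shown alone.

Series notes. In an assay on isolated protein for inhibition of Amine oxidase [flavin-containing] B (Homo sapiens), read by luminescence, with a stated time of 1 h (on this read-out lower numbers stand for stronger inhibition and higher numbers for weaker inhibition), compound 1 `Cn1c(=O)c2c(cc(/C=C/c3cccc(Cl)c3)n2C)n(C)c1=O` gives 1480 nM. Compound 2 `Cn1c(=O)c2c(cc(/C=C/c3ccc(S(C)(=O)=O)cc3)n2C)n(C)c1=O` is reported in this assay only as a limit, > 1000 nM, which is an assay limit and not a number. Going by the values given here, no step between compound 1 and compound 2 is established here; their two values stand side by side without a measured difference between them, and the limit for compound 2 leaves open where it actually sits (the limit of > 1000 nM in this assay, at which 1 of the 2 values shown sits).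

Compound 3 `Cn1c(=O)c2c(cc(/C=C/c3ccc(C#N)cc3)n2C)n(C)c1=O` has not been measured in this assay. It differs from compound 2 by cyano in place of methylsulfonyl on an aromatic carbon. Among the compounds with values here, with no measured step to lean on, the expected change from compound 2 to compound 3 is small, a step that the limit leaves unreadable from compound 2 to compound 3, not beyond the scatter in either direction. Compound 3 is therefore estimated at 2000 nM in this assay, with a range of 500 nM to 8000 nM.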

Compound 3, half-maximal inhibitory concentration: 543 nM
For compound 3 the middle estimate is 3.7-fold (0.57 log units) above the measured one; low and high end bracket the measured number.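

At this aromatic carbon, para to a large group, cyano in place of methylsulfonyl gives the series its first number in this assay for a group at this position, with an at least 1.8-fold lower number from compound 2 to compound 3 (0.26 log units; that floor lies within the scatter). That step is only a floor, and its true size stays unread because compound 2 is held only by an assay limit: the limit of > 1000 nM in this assay, at which 1 of the 3 values shown sits.

Setting 4-cyanophenyl in place of 3-chlorophenyl gives a 2.7-fold lower number from compound 1 to compound 3 (0.44 log units; beyond the scatter), though this swap changes both the group and its place on the ring, so neither is isolated.

Open is whether cyano itself or its position on the ring carries that step, since 3-cyanophenyl and 4-chlorophenyl do not appear among the compounds shown. Also open, from the compounds shown here alone, is how an amine or a carboxylic acid at this aromatic carbon would read.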